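Replacing the 5-methyl-1,2-oxazol-3-yl group of compound 2

The compounds below may be only part of what the source reports. "The series", "measured", "known", "first", "only" and "open" are said of these compounds alone.

For the measured compounds named here, in an ADME assay on the whole organism (Mus musculus, strain Swiss) for pharmacokinetics, read by LC-MS, with a stated time of 24 h, at a dose of 20 mg/kg by the oral route (a higher number here means more compound in the circulation at the dose given, a lower number less compound in the circulation), compound 1 (`Cc1c(Cc2ccc(C(F)(F)F)nc2)c[nH]c1C(=O)NC(C)c1cnn(C)c1`) reaches 36000 nM, while compound 2 (`Cc1cc(C(C)NC(=O)c2[nH]cc(Cc3ccc(C(F)(F)F)nc3)c2C)no1`) reaches 13000 nM, the lower of the two numbers so far. Compound 3 (`Cc1c(Cc2ccc(C(F)(F)F)nc2)c[nH]c1C(=O)NC(C)c1cn[nH]c1`) has not yet been measured. It carries 1H-pyrazol-4-yl in place of 5-methyl-1,2-oxazol-3-yl on a saturated chain carbon bound to an amide-type nitrogen and a saturated chain carbon.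

Going by the values given here, only one measured step bears on this change: a 2.8-fold lower number from compound 1 to compound 2 (0.44 log units; beyond the scatter), with 5-methyl-1,2-oxazol-3-yl in place of 1-methyl-1H-pyrazol-4-yl. Among the compounds with values here, compound 3 does not restore the group of compound 1, and no measured compound shows what 1H-pyrazol-4-yl itself gives, so this evidence is only partial. With compound 1 at 36000 nM, a modest move upward is expected, recovering only part of that earlier difference. The expected step is a 1.5-fold higher number from compound 2 to compound 3 (0.19 log units; within the scatter), and a result within the usual scatter would not be surprising. For compound 3, the estimated maximal plasma concentration is 20000 nM, with an expected range of 7000 nM to 55000 nM.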

Compound 3, maximal plasma concentration: 6400 nM
Compound 3: the middle estimate sits 3.1-fold (0.49 log units) above what was measured; the measured number lies below the stated range.
By their numbers in this assay, from the lowest: compound 3; then compound 2; then compound 1.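

In this assay the 1H-pyrazol-4-yl group gives the lowest number of the three compounds, with a 2.0-fold lower number from compound 2 to compound 3 (0.31 log units; beyond the scatter), so the number at this position also falls when the 5-methyl-1,2-oxazol-3-yl group gives way to this smaller ring, which carries a hydrogen-bond donor that the group it replaces lacks. The pair that differs least is more telling: with hydrogen in place of methyl on an aromatic nitrogen, the data show a 5.6-fold lower number from compound 1 to compound 3 (0.75 log units; beyond the scatter), so a single methyl on that nitrogen separates the highest and lowest numbers seen so far, a contrast that the earlier exchange of one whole ring for another could not isolate. No measurement shown explains why the maximal plasma concentration moves in this way.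

The compounds shown leave open whether an ethyl group or a longer chain on that aromatic nitrogen would keep, raise or lower the number seen with methyl. They also leave open whether the hydrogen-for-methyl exchange would give a similar step on a ring other than the pyrazole, such as a 1,2-oxazole carrying hydrogen in place of its methyl.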